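Swapping the aryl group on the core of compound 3

A few compounds are considered here, and "the series" means these few. Any claim that something is new, unique, unknown or untested is made for them only; others in the source may bear on it.

This account follows a set of compounds sharing the core of compound 1, whose structure is `CCCOC(=O)C1=C(C)NC(=O)NC1c1cccs1`. In an assay on membranes from HeLa cells for displacement of a labelled ligand from adenosine receptor A3 (Homo sapiens), read by scintillation counting, with a stated time of 180 min, tested at 1 uM (a higher number here means more inhibition at the concentration tested (going by the name of the read-out), a lower number less inhibition), compound 1 gives 32%. Among the compounds with values here, compound 2, `CCN(CC)C(=O)C1=C(C)NC(=O)NC1c1cccs1`, gives 31% in this assay, and the only measured single step, a number 1 percentage points lower from compound 1 to compound 2 (within the scatter), concerns the group on the carbonyl carbon rather than the aryl ring. Compound 3, `CC1=C(C(=O)OC2CCC2)C(c2ccoc2)NC(=O)N1`, gives 1% in this assay, the lowest of the three numbers shown; the values of compound 2 and compound 1 both lie above it by more than the scatter.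

Compound 4, `CC1=C(C(=O)OC2CCC2)C(c2cccs2)NC(=O)N1`, is not yet measured. It differs from compound 3 by thiophen-2-yl in place of furan-3-yl on a saturated ring carbon. Within the data shown here, no measured step changes the aryl ring, so the step from compound 1 to compound 2 does not bear on it. What is known is that compound 1 and compound 2, which carry thiophen-2-yl, both show clearly higher inhibition than compound 3 with furan-3-yl. The expected step is therefore a rise, a number 26 percentage points higher from compound 3 to compound 4 (beyond the scatter), and compound 4 is estimated at 27%, within 8% to 45%.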

Compound 4, a percentage reported as inhibition, at one concentration (the size of the read-out at that concentration, not a potency): 2%
The estimate for compound 4 lay 25 percentage points above the measured number, and the stated range ends above it.
By their numbers in this assay, from the lowest: compounds 3 and 4 (each within the scatter of the next); then compounds 2 and 1 (each within the scatter of the next).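

With the cyclobutyl ester held in place, thiophen-2-yl in place of furan-3-yl on the saturated ring carbon gave no readable change in this assay (a number 1 percentage points higher from compound 3 to compound 4 (within the scatter)). Within the data shown here, with thiophen-2-yl held in place, the gap to the earlier compounds appears at the carbonyl group instead, both for cyclobutyl in place of propyl on the oxygen (a number 30 percentage points lower from compound 1 to compound 4 (beyond the scatter)) and for cyclobutyloxy in place of diethylamino (a number 29 percentage points lower from compound 2 to compound 4 (beyond the scatter)). No measurement shown here explains these differences.

On these data alone, the aryl change can be read only alongside the cyclobutyl ester, so whether furan-3-yl would match thiophen-2-yl alongside propoxy or diethylamino stays open. Also open, as far as these compounds go, is how a phenyl ring on the saturated ring carbon, or a butyl chain on the ester oxygen, would compare.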